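The compounds below may be only part of what the source reports. "The series", "measured", "known", "first", "only" and "open" are said of these compounds alone.

Measured compounds in a functional assay for inhibition of metabotropic glutamate receptor 5 (Homo sapiens), read by FLIPR and calcium flux; on this read-out higher numbers stand for weaker inhibition and lower numbers for stronger inhibition:

Compound 1, `FC(F)(F)c1ccc(Sc2ccnc(-c3ccccn3)n2)cc1`, gives 210 nM.
Compound 2, `CC(=O)N(c1ccc(Cl)cc1)c1ccnc(-c2ccccn2)n1`, gives only an assay limit, > 10000 nM.
Compound 3, `Fc1ccc(Sc2ccnc(-c3ccccn3)n2)cc1F`, gives 1520 nM.

From the compounds shown here alone, compound 2 therefore has no number of its own in this assay; it sits at the limit of > 10000 nM in this assay, at which 1 of the 3 values shown sits, so all that is known is that it is the weakest of the three, and how much weaker stays open.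

Compound 4, `Clc1ccc(Nc2ccnc(-c3ccccn3)n2)cc1`, has not yet been measured. It differs from compound 2 in one place: hydrogen in place of acetyl on a nitrogen on an aromatic ring. In words, a hydrogen takes the place of the acetyl on the nitrogen that links the shared core to the chlorine-bearing ring. Within the data shown here, no measured pair among the three compounds shows a step of this kind, so the expectation has to come from the fact that compound 2 lies at the limit: a move from compound 2 to compound 4 is expected to go toward stronger inhibition, most likely by a step beyond the usual scatter, an at least 16-fold lower number from compound 2 to compound 4 (1.22 log units; beyond the scatter). On that basis compound 4 is estimated at 600 nM, with a range from 100 nM to 5000 nM.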

Compound 4, half-maximal inhibitory concentration: > 10000 nM
Compound 4 was reported as a limit; the forecaster's own chance of this, stated with the estimate: 15%; at least 16-fold (1.22 log units) between middle value and limit.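

Compound 2 and compound 4 both give only a limit rather than a number in this assay, so no step can be read between them: the limit of > 10000 nM in this assay, at which 2 of the 4 values shown sit.

From the compounds shown here alone, whether hydrogen in place of acetyl on that nitrogen changes inhibition at all stays open.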